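Nitro in place of fluoro: an expected step

The source may hold more compounds than are shown below. What is called first, only, known or untested is meant among the compounds shown, and "the series" means these compounds.

Two compounds have been measured in a functional assay on HCT-116 cells (Homo sapiens) for inhibition, read by MTT assay, with a stated time of 72 h; a lower number here means a stronger inhibitor, a higher number a weaker inhibitor:

Compound 1 `O=C1Nc2ccc(Cl)cc2/C1=N/NC(=S)N1CCN(c2ccccc2)CC1` gives 3490 nM.
Compound 2 `O=C1Nc2ccc(Cl)cc2/C1=N/NC(=S)N1CCN(c2ccccc2F)CC1` gives 8290 nM.

Within the data shown here, compound 2 stands with the highest of the two numbers; its nearest neighbour is compound 1, and the only measured step, a 2.4-fold higher number from compound 1 to compound 2 (0.38 log units; beyond the scatter), was a modest one, beyond the scatter, in the direction of weaker inhibition.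

Compound 3 `O=C1Nc2ccc(Cl)cc2/C1=N/NC(=S)N1CCN(c2ccccc2[N+](=O)[O-])CC1` differs from compound 2 in a single place: nitro in place of fluoro on an aromatic carbon. Among the measured compounds shown here, no measured pair involves a nitro group, so the step from compound 1 to compound 2 is the only one that speaks to a change at this position, and it shows that a substituent there moved the number only modestly. On that basis a step of similar size or none beyond the scatter is expected in this assay, if anything towards a higher number, as a 1.2-fold higher number from compound 2 to compound 3 (0.08 log units; within the scatter) is estimated.

Compound 3 is therefore expected to give about 10000 nM, within a range from 3500 nM to 30000 nM.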

Compound 3, half-maximal inhibitory concentration: 4570 nM
Estimate against measurement, compound 3: 2.2-fold (0.34 log units) above, and the stated range covers the measured number.
By their numbers in this assay, from the lowest: compounds 1, 3 and 2 (each within the scatter of the next, the first and the last beyond it).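

In this assay nitro in place of fluoro gives a 1.8-fold lower number from compound 2 to compound 3 (0.26 log units; within the scatter) and nitro in place of hydrogen gives a 1.3-fold higher number from compound 1 to compound 3 (0.12 log units; within the scatter) so the nitro compound cannot be told apart from either neighbour, even though those two neighbours are separated by a 2.4-fold higher number from compound 1 to compound 2 (0.38 log units; beyond the scatter) in this same read-out. The earlier pair alone could be read as saying that any substituent ortho to a large group raises the number, but that reading now rests on fluoro only: compound 3, with 3 heavy atoms in the entering group against 1 in fluoro, goes against it, staying within the scatter of the compound that carries hydrogen there. Nothing measured here bears on why fluoro and nitro read as they do.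

The compounds shown leave open whether an amine, a carboxylic acid or a methoxy group at this place would stay as close to compound 1 as compound 3 does, or move beyond the scatter as compound 2 does. They also leave open how a nitro group would read elsewhere on the same ring, and whether these readings carry over to any other cell line.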